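Compound 4: One Stereocentre Left Undrawn

The compounds below may be only part of what the source reports. "The series", "measured", "known", "first", "only" and "open" are said of these compounds alone.

In a functional assay on DU-145 cells (Homo sapiens) for cytotoxicity, read by MTT assay (a higher number here means a weaker inhibitor, a lower number a stronger inhibitor), compound 1 `CC(C)=CC[C@@H](OC[C@@H](C)O)C1=CC(=O)c2c(O)ccc(O)c2C1=O` gives 14300 nM, the lowest of the three measured numbers and beyond the scatter from both others. Compound 2 `CCCCC(CC(=O)O[C@H](CC=C(C)C)C1=CC(=O)c2c(O)ccc(O)c2C1=O)OC(C)=O` gives 67700 nM, and compound 3 `CCCC(CC(=O)O[C@H](CC=C(C)C)C1=CC(=O)c2c(O)ccc(O)c2C1=O)OC(C)=O` gives 55700 nM. Compound 4 `CC(C)=CC[C@@H](OCC(C)O)C1=CC(=O)c2c(O)ccc(O)c2C1=O` has the same atoms and bonds as compound 1: the two compounds have the same atoms and bonds; at least one stereo element is drawn with a configuration in one of them and without one in the other: 1 of 2 stereo elements differ; a stereocentre at a saturated chain carbon is drawn R in compound 1 and without a configuration in compound 4. Among the compounds with values here, the only measured step, a 1.2-fold lower number from compound 2 to compound 3 (0.08 log units; within the scatter), lies within the scatter and involves no stereocentre, so it bears only indirectly on this change. Within the data shown here, no measured pair compares configurations at this carbon, so no shift beyond the scatter is expected in this assay. The expected change is a 1.0-fold higher number from compound 1 to compound 4 (0.02 log units; within the scatter), in no clear direction. For compound 4 the estimated value is 15000 nM, with an expected range of 8000 nM to 28000 nM.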

Compound 4, half-maximal inhibitory concentration: 16100 nM
Compound 4: the middle estimate sits 1.1-fold (0.03 log units) below what was measured; the measured number falls inside the stated range.
By their numbers in this assay, from the lowest: compounds 1 and 4 (each within the scatter of the next); then compounds 3 and 2 (each within the scatter of the next).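

In this assay, the step at this saturated chain carbon is a 1.1-fold higher number from compound 1 to compound 4 (0.05 log units; within the scatter), so leaving the configuration undrawn goes with no change beyond the scatter. The earlier compounds shown here offered no comparison at this stereocentre, and this pair now gives one, though only between a drawn and an undrawn centre. What separates the two compounds is solely this: the fact that one of compounds 1 and 4 is drawn with a defined configuration and the other without, at the place where they differ.

The compounds shown leave open whether the opposite drawn configuration at this carbon would give a similar number. They also leave open whether an amine in place of the hydroxyl on this chain would shift it.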